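The source may hold more compounds than are shown below. What is called first, only, known or untested is meant among the compounds shown, and "the series" means these compounds.

In a functional assay on A549 cells (Homo sapiens) for inhibition, read by MTT assay, with a stated time of 48 h (on this read-out higher numbers stand for weaker inhibition and lower numbers for stronger inhibition), compound 1 (`Cn1c(/C=C2\SC(=O)N(CC(=O)Nc3cc(C(C)(C)C)on3)C2=O)nc2ccccc21`) gives 15300 nM. Compound 2 (`Cn1c(/C=C2\SC(=O)N(CC(=O)N3CCCCC3)C2=O)nc2ccccc21`) reports only a limit, > 50000 nM. The comparison of these two shows an at least 3.2-fold higher number from compound 1 to compound 2 (0.51 log units; beyond the scatter). Compound 3 (`CC(C)n1c(/C=C2\SC(=O)N(CC(=O)N3CCCC3)C2=O)nc2ccccc21`) also stands at a limit, > 50000 nM, so it has no number of its own. Together these two results make up (the limit of > 50000 nM in this assay, at which 2 of the 3 values shown sit).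

Compound 4 (`Cn1c(/C=C2\SC(=O)N(CC(=O)N3CCCC3)C2=O)nc2ccccc21`) keeps the rest of compound 3 and has methyl in place of isopropyl on an aromatic nitrogen. Among the compounds with values here, no measured step changes the group at that place. Within the data shown here, the single measured step lies on a carbonyl carbon, so it offers only indirect guidance on the size of this change. The closest evidence is compound 2, which also carries methyl on that aromatic nitrogen and reports the limit > 50000 nM.

No step beyond the scatter is therefore expected in this assay, and a further limit is the likely outcome. The expected change is a number no higher from compound 3 to compound 4 (the limit leaves the size open). For compound 4, the estimated value is 50000 nM, with an expected range from 25000 nM to 100000 nM.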

Compound 4, half-maximal inhibitory concentration: > 50000 nM
Compound 4: only a limit was reported (the forecaster's own chance of this, stated with the estimate: 75%); the middle value sits exactly at the limit.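

In this assay compound 4 gives > 50000 nM, which is a limit of the assay, so with pyrrolidin-1-yl on the carbonyl carbon, neither methyl nor isopropyl on the aromatic nitrogen yields a number, and the steps from compound 3 and from compound 2 to compound 4 cannot be read. Within the data shown here, the one step that can be read lies on the carbonyl carbon, an at least 3.2-fold higher number from compound 1 to compound 4 (0.51 log units; beyond the scatter), and it adds a second ring amine, pyrrolidin-1-yl after piperidin-1-yl, that takes the place of the (5-(tert-butyl)-1,2-oxazol-3-yl)amino group with a change beyond the scatter. Compound 1 remains the only compound shown with a number of its own, and the other results collect at one limit: the limit of > 50000 nM in this assay, at which 3 of the 4 values shown sit.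

Among these compounds, how methyl and isopropyl compare on the aromatic nitrogen stays open, as their only comparison sits at the limit, and a pairing of isopropyl with the (5-(tert-butyl)-1,2-oxazol-3-yl)amino group would be needed to give it a size. Also open, from the compounds shown here alone, is whether a benzyl group on that nitrogen, or an anilino or morpholin-4-yl group on the carbonyl carbon, would give a number in this assay.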